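Working notes on compounds 1 to 3

The source may hold more compounds than are shown below. What is called first, only, known or untested is meant among the compounds shown, and "the series" means these compounds.

Compound 1 `O=C(NCCCCc1ccccc1)n1c(=O)oc2cc(C3CCCCC3)ccc21` and compound 2 `CC(C)CN1CCC(c2ccc3c(c2)oc(=O)n3C(=O)NCCCCc2ccccc2)CC1` share one core and differ at a single aromatic carbon. In an assay on HEK293 cells for inhibition of acid ceramidase (Homo sapiens), read by fluorescence, with stated times of 10 min and 3 h (on this read-out lower numbers stand for stronger inhibition and higher numbers for weaker inhibition), compound 1 gives 89 nM and compound 2 gives 120 nM. Compound 2 holds the higher of the two numbers, yet the step of a 1.3-fold higher number from compound 1 to compound 2 (0.13 log units; within the scatter) keeps it within the scatter of compound 1. Compound 3 `CCN1CCN(c2ccc3c(c2)oc(=O)n3C(=O)NCCCCc2ccccc2)CC1` is the next variation on the same core: 4-ethylpiperazin-1-yl in place of 1-isobutylpiperidin-4-yl on an aromatic carbon. Within the data shown here, the only measured step that relates to this change is the one from compound 1 to compound 2, which exchanged a ring of carbon only for a ring carrying nitrogen; its size, a 1.3-fold higher number from compound 1 to compound 2 (0.13 log units; within the scatter), gives no sign that a nitrogen-bearing ring at this position moves the number beyond the scatter. The change to compound 3 is of a different kind, and nothing measured speaks for a step in either direction. The step expected in this assay is a 1.3-fold higher number from compound 2 to compound 3 (0.10 log units; within the scatter). For compound 3 the estimate is 150 nM, with a range from 60 nM to 400 nM.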

Compound 3, half-maximal inhibitory concentration: 56 nM
Beside the measured number, compound 3's estimate is 2.7-fold (0.43 log units) above it, outside the stated range (below it).
By their numbers in this assay, from the lowest: compounds 3, 1 and 2 (each within the scatter of the next, the first and the last beyond it).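

In this assay, among these compounds, 4-ethylpiperazin-1-yl in place of 1-isobutylpiperidin-4-yl gives a 2.1-fold lower number from compound 2 to compound 3 (0.33 log units; beyond the scatter), the first step at this aromatic carbon to pass beyond the scatter, so the number here does respond to a change between two nitrogen-bearing rings. Set against cyclohexyl, the same group gives a 1.6-fold lower number from compound 1 to compound 3 (0.20 log units; within the scatter), so compound 3 and compound 1 remain indistinguishable, and only compound 2 and compound 3 stand apart. Nothing available explains the step from the piperidine to the piperazine.

The step from compound 2 to compound 3 changes the ring and its nitrogen substituent together, so the contribution of each remains unresolved. A 1-ethylpiperidin-4-yl group would separate the two, while a morpholine ring would test whether a second ring nitrogen is needed at this position.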